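A few compounds are considered here, and "the series" means these few. Any claim that something is new, unique, unknown or untested is made for them only; others in the source may bear on it.

Compound 1 `O=C1NCCN1c1ccc(S(=O)(=O)Nc2ccc(OC(F)F)cc2)cc1` carries a difluoromethoxy group on one of its aromatic rings. Within the data shown here, in a functional assay on HT-29 cells (Homo sapiens) for antiproliferative activity, read by sulforhodamine B assay, with a stated time of 48 h (a lower number here means a stronger inhibitor, a higher number a weaker inhibitor), compound 1 gives 650 nM and stands highest of the two numbers measured so far. Its nearest neighbour, compound 2 `COc1cccc(NS(=O)(=O)c2ccc(N3CCNC3=O)cc2)c1`, gives 120 nM in this assay, a lower number that lies beyond the scatter. Compound 3 `CCCCCCCc1ccc(NS(=O)(=O)c2ccc(N3CCNC3=O)cc2)cc1` has not been measured yet; it differs from compound 1 by heptyl in place of difluoromethoxy on an aromatic carbon on the ring. Among the measured compounds shown here, no measured pair shows this particular change, so the step is expected to be a 1.6-fold lower number from compound 1 to compound 3 (0.21 log units; within the scatter) toward a lower number, a shift that may stay close to the scatter. Compound 3 is accordingly estimated at 400 nM with a range from 120 nM to 1500 nM in this assay.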

Compound 3, half-maximal inhibitory concentration: > 1000 nM
Compound 3: no number, only a limit; the forecaster's own chance of this, stated with the estimate: 5%; middle value at least 2.5-fold (0.39 log units) away from the limit.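

This position now carries a plain carbon chain: in this assay compound 3 gives > 1000 nM, a limit and not a number. Heptyl in place of difluoromethoxy gives an at least 1.5-fold higher number from compound 1 to compound 3 (0.18 log units; that floor lies within the scatter), so heptyl brings no lower number here, although that floor alone does not establish a real loss. Only a floor can be given for this step, because the reading ends at a limit: the limit of > 1000 nM in this assay, at which 1 of the 3 values shown sits.

Going by these compounds, the true size of the step stays open. So does how an ethyl chain, an amine or a carboxylic acid would read on this aromatic carbon.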